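The source may report more compounds than this note shows. Statements on the series, on what has been measured and on what is new or still open speak of the compounds shown alone.

Compound 1 `CCN(CC)S(=O)(=O)c1ccc(S(=O)(=O)N2CCC[C@@H](C(=O)N3CCOCC3)C2)cc1`: 160 nM
Compound 2 `CCN(CC)S(=O)(=O)c1ccc(S(=O)(=O)N2CCC[C@@H](C(=O)N3CC[C@@H](OC)C3)C2)cc1`: 1070 nM

Of the compounds shown here, two have been measured in a functional assay on MIA PaCa-2 cells (Homo sapiens) for inhibition, read by MTT assay, with a stated time of 3 days; a lower number here means a stronger inhibitor, a higher number a weaker inhibitor. For the measured compounds named here, compound 2 gives the higher of the two numbers; its nearest neighbour, compound 1, gives 160 nM, and the one step between them, a 6.7-fold higher number from compound 1 to compound 2 (0.83 log units; beyond the scatter), came with the replacement of morpholin-4-yl by 3-methoxypyrrolidin-1-yl on a carbonyl carbon.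

Compound 3 `CCN(CC)S(=O)(=O)c1ccc(S(=O)(=O)N2CCC[C@@H](C(=O)N3CC[C@H](OC)C3)C2)cc1` has not yet been measured. It differs from compound 2 only in configuration: the two compounds have the same atoms and bonds and differ only in configuration as drawn: 1 of 2 stereo elements differ; a stereocentre at a saturated ring carbon is drawn R in compound 2 and S in compound 3. Going by the values given here, no measured step touches a configuration; the single step known, from morpholin-4-yl to 3-methoxypyrrolidin-1-yl, swaps whole groups and so says nothing about which way a mirror arrangement at one ring carbon will move the number. Without such a guide, the expectation for compound 3 in this assay is no step beyond the scatter, a 1.2-fold lower number from compound 2 to compound 3 (0.08 log units; within the scatter), held with wide uncertainty in either direction. Compound 3 is therefore estimated at 900 nM, within a range from 300 nM to 3000 nM.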

Compound 3, half-maximal inhibitory concentration: 460 nM
Compound 3: middle estimate off by 2.0-fold (0.29 log units), on the high side; measured number inside the range.
By their numbers in this assay, from the lowest: compound 1; then compound 3; then compound 2.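

In this assay, the stereocentre at a saturated ring carbon matters in its own right, with a step of a 2.3-fold lower number from compound 2 to compound 3 (0.37 log units; beyond the scatter), so the drawn arrangement there can shift the number even when no atom or bond changes. It also refines the group swap: replacing morpholin-4-yl with 3-methoxypyrrolidin-1-yl gives a 2.9-fold higher number from compound 1 to compound 3 (0.46 log units; beyond the scatter) with the S arrangement, a smaller step than a 6.7-fold higher number from compound 1 to compound 2 (0.83 log units; beyond the scatter) with the R arrangement, yet both arrangements still give higher numbers than the morpholine amide, compound 1. The gap between compound 2 and compound 3 can be placed on the configuration at this one carbon, because nothing else separates the pair: the fact that compounds 2 and 3 differ only in the configuration as drawn.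

Still open, on these data alone, is whether the same preference for S over R would hold if an amine or a hydroxyl group took the place of the methoxy group on the pyrrolidine. The second stereocentre, drawn the same way in all three compounds, also remains untested, so its contribution to these numbers cannot be told from the compounds shown.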